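A few compounds are considered here, and "the series" means these few. Any claim that something is new, unique, unknown or untested is made for them only; others in the source may bear on it.

Three compounds share one core and differ only in the aromatic group attached to the carbon that carries a double bond to nitrogen. Compound 1 `COc1ccc(/C=N/NC(=O)Nc2ccc(Oc3ccnc4cc(OCCCN5CCCCC5)c(OC)cc34)c(F)c2)cc1` gives 840 nM in a functional assay on MDA-MB-231 cells (Homo sapiens) for cytotoxicity, read by MTT assay, with a stated time of 72 h; a higher number here means a weaker inhibitor, a lower number a stronger inhibitor. Compound 2 `COc1cc2c(Oc3ccc(NC(=O)N/N=C/c4ccc(F)cc4Cl)cc3F)ccnc2cc1OCCCN1CCCCC1` gives 790 nM in this assay, and compound 3 `COc1cc2c(Oc3ccc(NC(=O)N/N=C/c4ccc(N(C)C)cc4)cc3F)ccnc2cc1OCCCN1CCCCC1` gives 1400 nM in this assay. The change from compound 1 to compound 2 produced a 1.1-fold lower number from compound 1 to compound 2 (0.03 log units; within the scatter), the change from compound 1 to compound 3 produced a 1.7-fold higher number from compound 1 to compound 3 (0.22 log units; within the scatter), and the change from compound 2 to compound 3 produced a 1.8-fold higher number from compound 2 to compound 3 (0.25 log units; within the scatter). Compound 3 therefore stands with the highest of the three numbers, yet its steps to compound 1 and to compound 2 both lie within the scatter, so no order among the three compounds can be claimed.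

Compound 4 `COc1cc2c(Oc3ccc(NC(=O)N/N=C/c4cccs4)cc3F)ccnc2cc1OCCCN1CCCCC1` takes the same position once more: thiophen-2-yl in place of 4-(dimethylamino)phenyl on a carbon with a double bond to nitrogen. Going by the values given here, every measured step so far has swapped one aromatic group for another on this carbon, and none of them moved the number beyond the scatter. On that basis the step from compound 3 to compound 4 is expected to be small, a 1.4-fold lower number from compound 3 to compound 4 (0.15 log units; within the scatter), with no clear direction beyond the scatter. Compound 4 is expected to give about 1000 nM in this assay, with a range from 450 nM to 2500 nM.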

Compound 4, half-maximal inhibitory concentration: 1260 nM
For compound 4 the middle estimate is 1.3-fold (0.10 log units) below the measured one; low and high end bracket the measured number.
By their numbers in this assay, from the lowest: compounds 2, 1, 4 and 3 (each within the scatter of the next).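

Going by these compounds alone, compound 4 places a five-membered aromatic ring with a sulfur atom on this carbon, where the earlier compounds all carry a six-membered aromatic ring of carbon only. This different ring leaves every comparison within the scatter in this assay, with a 1.1-fold lower number from compound 3 to compound 4 (0.05 log units; within the scatter) and a 1.6-fold higher number from compound 2 to compound 4 (0.20 log units; within the scatter) and, against the third earlier compound, a 1.5-fold higher number from compound 1 to compound 4 (0.18 log units; within the scatter) as the three new steps. Across these four compounds, then, the position accepts a change in ring size and ring atoms with no step that can be told from the scatter, but no measurement shown here bears on what lies behind this result.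

From the compounds shown here alone, all four compounds carry an aromatic ring on this carbon, so it remains open what a plain alkyl chain, a carboxylic acid or an amine would give in its place. It also remains open whether any group at this position can produce a step beyond the scatter, since the four aromatic groups shown cannot be ranked against one another.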